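The source may hold more compounds than are shown below. What is called first, only, known or untested is meant among the compounds shown, and "the series" means these compounds.

Of the compounds shown here, three sharing one core have been measured in a functional assay on Jurkat cells (Homo sapiens) for cytotoxicity, read by MTT assay, with a stated time of 24 h; on this read-out higher numbers stand for an effect only at larger amounts of compound and lower numbers for an effect already at smaller amounts. Compound 1, `CCCCC#Cc1cc(C(=O)OCC)nc2ccc(OC)cc12`, gives 15900 nM. Among the compounds with values here, compound 2, `CCOC(=O)c1cc([Te]c2ccccc2)c2cc(OC)ccc2n1`, gives 77400 nM, and the step of a 4.9-fold higher number from compound 1 to compound 2 (0.69 log units; beyond the scatter) is the only step between two measured compounds that differ in a single place. Compound 3, `CCOC(=O)c1cc([Se]Cc2ccccc2)c2cc(Cl)ccc2n1`, gives 88500 nM; this is the highest of the three numbers, although its gap to compound 2 lies within the scatter, while its gap to compound 1 lies beyond it. Compound 4, `CCOC(=O)c1cc([Se]Cc2ccccc2)c2cc(Br)ccc2n1`, has not yet been measured in this assay. Within the data shown here, it differs from compound 3 in one place: bromo in place of chloro on an aromatic carbon No measured step involves bromo in place of chloro; the single measured step concerns a different exchange on another aromatic carbon and does not bear on this one. With no guide in the data, no step beyond the scatter is expected for a 1.0-fold lower number from compound 3 to compound 4 (0.00 log units; within the scatter). Compound 4 is therefore estimated at 88000 nM, with a range from 40000 nM to 200000 nM.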

Compound 4, half-maximal effective concentration: 53600 nM
Compound 4: the middle estimate sits 1.6-fold (0.22 log units) above what was measured; measured number inside the range.
By their numbers in this assay, from the lowest: compound 1; then compounds 4, 2 and 3 (each within the scatter of the next).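

In this assay the exchange of chloro for bromo gives a 1.7-fold lower number from compound 3 to compound 4 (0.22 log units; within the scatter), so on this aromatic carbon, meta to a fused ring and para to a fused ring, the two halogens cannot be told apart. The earlier compounds shown here offered no step at this place; this one shows that replacing one halogen with another, with no change in the count of rings, hydrogen-bond donors or hydrogen-bond acceptors, stays within the scatter. No measured property bears on this result, and nothing shown accounts for it.

Going by these compounds, whether an amine or a carboxylic acid on this carbon would give a step beyond the scatter remains open. So does whether bromo in place of chloro would stay within the scatter with the alkyne chain of compound 1 on the shared core.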